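The compounds below may be only part of what the source reports. "The series", "measured", "known", "first", "only" and "open" are said of these compounds alone.

In a functional assay on cells (Cancer cell lines, Homo sapiens) for cytotoxicity, with a stated time of 48 h (on this read-out lower numbers stand for stronger inhibition of growth and higher numbers for weaker inhibition of growth), three related compounds have numbers: compound 1 `COc1cc(/C=C2/C(=O)N(C)c3ccc(O)cc32)cc(OC)c1OC` gives 17400 nM while compound 2 `COc1ccc2c(c1)/C(=C\c1cc(OC)c(OC)c(OC)c1)C(=O)N2C` gives 14100 nM and compound 3 `COc1cc(/C=C2\C(=O)N(Cc3ccc(Cl)cc3)c3ccccc32)cc(OC)c1OC` gives 15100 nM and these numbers all lie within the usual scatter of one another. Compound 2 therefore stands level with the other two. Compound 4 `COc1ccc(CN2C(=O)/C(=C/c3cc(OC)c(OC)c(OC)c3)c3cc(OC)ccc32)cc1` differs from compound 2 by 4-methoxyphenyl in place of hydrogen on a saturated chain carbon bound to an amide-type nitrogen in a ring. For the measured compounds named here, the only measured step (a 1.2-fold lower number from compound 1 to compound 2 (0.09 log units; within the scatter)) is a methyl in place of hydrogen on an oxygen on an aromatic ring, a different change that bears only loosely on this one. Closer is compound 3, which also carries a benzyl-type group, a chlorinated one, and compound 3 gives 15100 nM within the scatter of compound 2. No step beyond the scatter is therefore expected in this assay in either direction. The expected step is small (a 1.0-fold lower number from compound 2 to compound 4 (0.00 log units; within the scatter)). For compound 4 the expected value is 14000 nM within an estimated range (7000 nM to 28000 nM).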

Compound 4, concentration for total growth inhibition: 7400 nM
For compound 4 the middle estimate is 1.9-fold (0.28 log units) above the measured one; the range from low to high includes it.
By their numbers in this assay, from the lowest: compounds 4, 2, 3 and 1 (each within the scatter of the next, the first and the last beyond it).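

For the compounds shown here, putting 4-methoxyphenyl in place of hydrogen on a saturated chain carbon bound to an amide-type nitrogen in a ring, which turns a methyl into a 4-methoxybenzyl, gives a 1.9-fold lower number from compound 2 to compound 4 (0.28 log units; within the scatter) in this assay and is the only single-place reading at this position. The earlier step touched an oxygen on an aromatic ring, so only now is it visible that a whole aromatic ring can enter on this carbon without the number leaving the usual scatter. Nothing at hand accounts for the size of this step.

The compounds shown leave open how a longer chain without an aromatic ring would read on this nitrogen. They also leave open what an amine or a carboxylic acid in place of the 4-methoxyphenyl would do to the number.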